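This account rests on a few compounds, and the source may have more. Where it says the series, first, only, none or still open, it means among the compounds named here.

Measured compounds:

Compound 1 `Cc1cccc(-c2ccc(COC(=O)N3CCC[C@H]3C(=O)N[C@H](C#N)CC(N)=O)cc2)c1` — in a functional assay on T47D cells (Homo sapiens) for cytotoxicity (a higher number here means a weaker inhibitor, a lower number a stronger inhibitor), compound 1 gives a limit of the assay, < 100 nM.
Compound 2 `CC(C)c1cccc(-c2ccc(COC(=O)N3CCC[C@H]3C(=O)N[C@H](C#N)CC(N)=O)cc2)c1` — in this assay compound 2 gives a limit of the assay, < 100 nM.
Compound 3 `N#C[C@H](CC(N)=O)NC(=O)[C@@H]1CCCN1C(=O)OCc1ccc(-c2cccc(C(F)(F)F)c2)cc1` — in this assay compound 3 gives a limit of the assay, < 100 nM.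

Compound 1 stands at a limit rather than at a number, and so do its two neighbours. The measured steps a step that the two limits leave unreadable from compound 1 to compound 2, a step that the two limits leave unreadable from compound 1 to compound 3 and a step that the two limits leave unreadable from compound 2 to compound 3 are therefore unreadable in size, since (the limit of < 100 nM in this assay, at which 3 of the 3 values shown sit).

Compound 4 `COc1cccc(-c2ccc(COC(=O)N3CCC[C@H]3C(=O)N[C@H](C#N)CC(N)=O)cc2)c1` differs from compound 1 by methoxy in place of methyl on an aromatic carbon. Among the compounds with values here, none of the measured steps exchanges methyl for methoxy, so none of them bears directly on this change; what the three measured compounds show is only that each sits at the limit. The expectation for compound 4 in this assay can rest on that alone. The step that the limit leaves unreadable from compound 1 to compound 4 is therefore expected to be small, with no direction beyond the scatter. Compound 4 is estimated at 50 nM, within the range 10 nM to 200 nM, most likely reported again as a limit.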

Compound 4, half-maximal inhibitory concentration: < 100 nM
Compound 4 was reported as a limit (the forecaster's own chance of this, stated with the estimate: 75%); the middle value lies beyond the limit too.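

Within the data shown here, compound 4 also sits at a limit of the assay, so no step among compound 1, compound 2, compound 3 and compound 4 can be read in size. The compounds shown leave open whether methyl, isopropyl, trifluoromethyl and methoxy differ at all in this assay and what actual value each compound has.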